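Smaller amino ring on the shared core of compound 1

The source may report more compounds than this note shows. Statements on the series, on what has been measured and on what is new or still open speak of the compounds shown alone.

Compound 1 `CC(=O)Nc1cc(Nc2cc(NC3CC3)n3ncc(C#N)c3n2)ccc1N1CCC[C@@H](N)C1` is followed here in an ADME assay on cells (Hepatocyte, Rattus norvegicus) for metabolic stability; a higher number here means faster removal of the compound, a lower number slower removal. In this assay compound 1 gives < 1 uL/min, a limit of the assay rather than a measured number. Compound 1 thus stands at the limit of < 1 uL/min in this assay, at which 1 of the 2 values shown sits. Compound 2 `CC(=O)Nc1cccc(Nc2cc(NC3CC3)n3ncc(C#N)c3n2)c1` gives 26 uL/min in this assay. Among the measured compounds shown here, the one measured step, an at least 26-fold higher number from compound 1 to compound 2 (1.41 log units; beyond the scatter), removes the whole 3-aminopiperidin-1-yl group, whereas compound 3 `CC(=O)Nc1cc(Nc2cc(NC3CC3)n3ncc(C#N)c3n2)ccc1N1CC[C@H](N)C1` only exchanges it: 3-aminopyrrolidin-1-yl in place of 3-aminopiperidin-1-yl on an aromatic carbon. Since the group itself stays, no step beyond the scatter is expected, a number no lower from compound 1 to compound 3 (the limit leaves the size open). Compound 3 is therefore estimated at 1 uL/min, with a range from 0.5 uL/min to 3 uL/min.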

Compound 3, intrinsic clearance in a liver preparation (reported as CLH), per the amount of preparation that the assay uses: < 1 uL/min
Compound 3: a limit, no number (the forecaster's own chance of this, stated with the estimate: 55%); the middle value lies on the limit itself.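

In this assay, the five-membered 3-aminopyrrolidin-1-yl group in this position, ortho to the acetamido group, gives a limit, not a number, just as the six-membered 3-aminopiperidin-1-yl group does, so the step between compound 1 and compound 3 cannot be read. The smaller ring still stands far from hydrogen, with an at least 26-fold lower number from compound 2 to compound 3 (1.41 log units; beyond the scatter). Both ring sizes thus end at the same edge of the read-out: the limit of < 1 uL/min in this assay, at which 2 of the 3 values shown sit.

The compounds shown leave open how far the two rings differ beneath that limit. They also leave open whether the ring amine matters, which a hydroxyl group in its place would test.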